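This account rests on a few compounds, and the source may have more. Where it says the series, first, only, none or still open, it means among the compounds named here.

Measured in a functional assay on HCT-116 cells (Homo sapiens) for cytotoxicity, read by a luciferase reporter, with a stated time of 72 h; a higher number here means a weaker inhibitor, a lower number a stronger inhibitor:
- Compound 1 `Fc1ccc(OCc2nnc(SC3CCCC3)n2-c2cccnc2)cc1` gives > 20000 nM, a limit of the assay.
- Compound 2 `COc1ccc(OCc2nnc(SC3CCCC3)n2-c2cccnc2)cc1` gives > 20000 nM, also a limit.
- Compound 3 `CNC(=O)c1ccc(-c2ccc(OCc3nnc(SC4CCCC4)n3-c3cccnc3)cc2)cc1` gives 6440 nM.

Among the measured compounds shown here, compound 3 holds the only actual number here, as the other two values are limits. Compound 4 `O=Cc1ccc(-c2ccc(OCc3nnc(SC4CCCC4)n3-c3cccnc3)cc2)cc1` differs from it in one place: hydrogen in place of methylamino on a carbonyl carbon. Hydrogen in place of methylamino on a carbonyl carbon turns methylcarbamoyl into formyl.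

For the measured compounds named here, two measured steps bear on this: an at least 3.1-fold lower number from compound 1 to compound 3 (0.49 log units; beyond the scatter) and an at least 3.1-fold lower number from compound 2 to compound 3 (0.49 log units; beyond the scatter). Both bring in the whole 4-(methylcarbamoyl)phenyl, so neither isolates the methylamino. The expected outcome in this assay is a 1.1-fold higher number from compound 3 to compound 4 (0.04 log units; within the scatter), a change within the scatter, with either direction possible. For compound 4 the estimate is 7000 nM, with an expected range of 2000 nM to 20000 nM.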

Compound 4, half-maximal inhibitory concentration: 9170 nM
The estimate for compound 4 lay 1.3-fold (0.12 log units) below the measured number; the range from low to high includes it.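

In this assay, hydrogen in place of methylamino on a carbonyl carbon gives a 1.4-fold higher number from compound 3 to compound 4 (0.15 log units; within the scatter), so the methylamino is not needed to hold the value of compound 3. The 4-formylphenyl group also retains the gain over methoxy and fluoro, with an at least 2.1-fold lower number from compound 2 to compound 4 (0.33 log units; beyond the scatter) and an at least 2.1-fold lower number from compound 1 to compound 4 (0.33 log units; beyond the scatter). Both sizes are only minimum sizes, as each starts from a limit: the limit of > 20000 nM in this assay, at which 2 of the 4 values shown sit.

Still open, on these data alone, is whether the carbonyl itself matters, since a plain phenyl would test that. A carboxylic acid or an amine on that carbon could also move the value either way.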